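The source may hold more compounds than are shown below. What is called first, only, known or untested is meant among the compounds shown, and "the series" means these compounds.

Measured in a functional assay on NALM-6 cells (Homo sapiens) for antiproliferative activity, read by MTT assay and trypan blue exclusion, with a stated time of 72 h; a higher number here means a weaker inhibitor, a lower number a stronger inhibitor:
- compound 1 `COC(=O)c1ccc(C2SCC(=O)N2c2ccc(N3CCN(Cc4cccc(C)c4)CC3)cn2)c(OC)c1`: 27300 nM
- compound 2 `COC(=O)c1ccc(C2SCC(=O)N2c2ccc(N3CCN(Cc4cccc([N+](=O)[O-])c4)CC3)cn2)c(OC)c1`: > 100000 nM (a limit of the assay, not a number)
- compound 3 `COC(=O)c1ccc(C2SCC(=O)N2c2ccc(N3CCN(S(=O)(=O)c4ccccc4)CC3)cn2)c(OC)c1`: 48400 nM

Only two of these compounds have true numbers, and the gap between them is small: a 1.8-fold higher number from compound 1 to compound 3 (0.25 log units; within the scatter). Compound 1 therefore cannot be ranked apart from compound 3, while compound 2 has only a limit.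

The next compound, compound 4 `COC(=O)c1ccc(C2SCC(=O)N2c2ccc(N3CCNCC3)cn2)c(OC)c1`, has hydrogen in place of 3-methylbenzyl on an amine nitrogen in a ring. Among the measured compounds shown here, no measured step removes the group from this nitrogen outright, so the evidence is indirect. Swapping the whole group for phenylsulfonyl gave a 1.8-fold higher number from compound 1 to compound 3 (0.25 log units; within the scatter), so that large change on the same nitrogen had no clear effect. Changing only the methyl to nitro gave an at least 3.6-fold higher number from compound 1 to compound 2 (0.56 log units; beyond the scatter), and the comparison between the two swapped groups gave an at least 2.0-fold lower number from compound 2 to compound 3 (0.31 log units; beyond the scatter). For the measured compounds named here, the group on this nitrogen can therefore matter, though these steps come from only three compounds.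

On this evidence, a modest move towards a higher number is expected in this assay, and the expected step, a 1.6-fold higher number from compound 1 to compound 4 (0.22 log units; within the scatter), may stay within the usual scatter. For compound 4 the estimated value is 45000 nM, with an expected range of 15000 nM to 100000 nM.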

Compound 4, half-maximal inhibitory concentration: 9710 nM
Compound 4: middle estimate off by 4.6-fold (0.67 log units), on the high side; the whole stated range lies above it.
By their numbers in this assay, from the lowest: compound 4; then compounds 1 and 3 (each within the scatter of the next). At a limit, above all of these: compound 2.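

In this assay, among the compounds shown here, the earlier compounds only traded one group on this amine nitrogen for another, whereas compound 4 shows what happens with no group there at all, and that bare nitrogen gives the strongest inhibitor of the four: a 2.8-fold lower number from compound 1 to compound 4 (0.45 log units; beyond the scatter), and a 5.0-fold lower number from compound 3 to compound 4 (0.70 log units; beyond the scatter), and an at least 10-fold lower number from compound 2 to compound 4 (1.01 log units; beyond the scatter). So among the compounds shown, neither 3-methylbenzyl, 3-nitrobenzyl nor phenylsulfonyl is needed for activity, and each of the three goes with a higher number than plain hydrogen, even though compounds 1 and 3 could not be told apart. The step from compound 2 gives only a minimum size, since compound 2 has a limit and not a true number: the limit of > 100000 nM in this assay, at which 1 of the 4 values shown sits.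

From the compounds shown here alone, it remains open whether a small group on this nitrogen, such as methyl, acetyl or a short alkyl chain, would keep the number as low as in compound 4 or lower it further. Going by these compounds, it is also open how far changes elsewhere on the shared core, such as a carboxylic acid in place of the methyl ester, would add to this gain.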